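The source may report more compounds than this note shows. Statements on the series, on what has been measured and on what is new or still open speak of the compounds shown alone.

Compound 1 `N#C/C(=C\c1c[nH]c2cc(F)ccc12)C(=O)c1c[nH]c2cc(F)ccc12` carries a fluoro group on each of its two indole parts. In a functional assay on PC-3 cells (Homo sapiens) for cytotoxicity, read by WST assay, with a stated time of 48 h (on this read-out higher numbers stand for weaker inhibition and lower numbers for stronger inhibition), compound 1 gives only a limit of the assay, > 50000 nM. Compound 3 `COc1ccc2c(C(=O)/C(C#N)=C/c3c[nH]c4cc(F)ccc34)c[nH]c2c1` differs from it by methoxy in place of fluoro on an aromatic carbon, and in this assay compound 3 gives 22500 nM. That change makes a step of an at least 2.2-fold lower number from compound 1 to compound 3 (0.34 log units; beyond the scatter), and the step can only be stated as an at-least figure because compound 1 sits at the limit of > 50000 nM in this assay, at which 2 of the 3 values shown sit. Compound 2 `N#C/C(=C\c1cn(Cc2ccc(Cl)cc2)c2ccccc12)C(=O)c1c[nH]c2cc(F)ccc12` has a different core; how the two cores differ is not broken down here. In this assay compound 2 gives a limit of the assay, > 50000 nM. Compound 4 `COc1ccc2c(C(=O)/C(C#N)=C/c3cn(Cc4ccc(Cl)cc4)c4ccccc34)c[nH]c2c1` is not yet measured and differs from compound 2 by methoxy in place of fluoro on an aromatic carbon, the same change as from compound 1 to compound 3 at the same kind of position. On that single earlier step, compound 4 is expected to show an at least 1.6-fold lower number from compound 2 to compound 4 (0.22 log units; that floor lies within the scatter), since compound 2 itself only reaches a limit. Compound 4 is therefore estimated at 30000 nM, within a range from 8000 nM to 100000 nM.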

Compound 4, half-maximal inhibitory concentration: > 50000 nM
Compound 4: no number, only a limit; the forecaster's own chance of this, stated with the estimate: 50%; middle value at least 1.6-fold (0.22 log units) away from the limit.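

In this assay compound 4 gives > 50000 nM, which is only a limit of the assay. Among these compounds, compound 2 also gives only a limit, so no step from compound 2 to compound 4 can be read: the limit of > 50000 nM in this assay, at which 3 of the 4 values shown sit. On these data alone, whether methoxy in place of fluoro changes the result for compound 2 and compound 4, as it does from compound 1 to compound 3, stays open.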